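The source may hold more compounds than are shown below. What is called first, only, known or untested is meant among the compounds shown, and "the series" means these compounds.

Among the measured compounds shown here, compound 2 `COc1cccc(/C=C/C(=O)c2cccc(-c3cccc(F)c3)c2)c1OC` is the only compound with a full number in an assay on A549 cells for inhibition of transcription factor p65 (Homo sapiens), read by fluorescence, with a stated time of 2 h (on this read-out lower numbers stand for stronger inhibition and higher numbers for weaker inhibition), where compound 2 gives 24100 nM. Compound 1 `COc1ccc(/C=C/C(=O)c2cccc(Br)c2)cc1OC` reaches only a limit in this assay, at which compound 1 gives > 50000 nM (the limit of > 50000 nM in this assay, at which 1 of the 2 values shown sits). Compound 3 `COc1ccccc1/C=C/C(=O)c1cccc(-c2cccc(F)c2)c1` differs from compound 2 by hydrogen in place of methoxy on an aromatic carbon. For the measured compounds named here, no measured pair shows this change, so the expected step in this assay is small, at most a slight weakening close to the scatter. Compound 3 is estimated at 30000 nM, with a range from 12000 nM to 75000 nM. The expected step is a 1.2-fold higher number from compound 2 to compound 3 (0.10 log units; within the scatter).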

Compound 3, half-maximal inhibitory concentration: 35300 nM
The estimate for compound 3 lay 1.2-fold (0.07 log units) below the measured number; low and high end bracket the measured number.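

In this assay, among the compounds shown here, hydrogen in place of methoxy on the aromatic carbon ortho to a methoxy group gives a 1.5-fold higher number from compound 2 to compound 3 (0.17 log units; within the scatter), the first measured step in this set. This methoxy group can therefore be replaced by hydrogen without a shift beyond the scatter, so the two compounds read alike. One value in the set is a limit and not a number: the limit of > 50000 nM in this assay, at which 1 of the 3 values shown sits.

The compounds shown leave open whether a different group on this carbon, such as an amine, a hydroxyl or a longer alkoxy chain, would move the number beyond the scatter.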